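The source may hold more compounds than are shown below. What is called first, only, known or untested is meant among the compounds shown, and "the series" means these compounds.

Compound 1 `OC[C@H]1C[C@@H](Cn2cnc3c(-c4ccc(Cl)cc4)ncnc32)c2ccccc21`: 0.63 ug/mL
Compound 2 `CCCNc1ncnc2c1ncn2C[C@@H]1C[C@H](CO)c2ccccc21`: 24 ug/mL

Both values come from a functional assay on CCRF-CEM cells (Homo sapiens); on this read-out higher numbers stand for weaker inhibition and lower numbers for stronger inhibition. Compound 2 carries the higher of the two numbers, so it is the weaker inhibitor of the pair. Compound 3 `OC[C@H]1C[C@@H](Cn2cnc3c(NC4CC4)ncnc32)c2ccccc21` differs from compound 2 in one place: cyclopropyl in place of propyl on a nitrogen on an aromatic ring. In words, cyclopropyl stands in place of propyl on a nitrogen on an aromatic ring.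

Going by the values given here, only one measured step bears on this: a 38-fold higher number from compound 1 to compound 2 (1.58 log units; beyond the scatter). It is large, but it swapped 4-chlorophenyl for propylamino on an aromatic carbon, a much bigger change than this one. Among the compounds with values here, no measured pair compares propyl with cyclopropyl directly, so compound 2, at 24 ug/mL, remains the closest guide. The expected size is a 1.2-fold lower number from compound 2 to compound 3 (0.08 log units; within the scatter), which is no step beyond the scatter. Compound 3 is estimated at 20 ug/mL, with an expected range from 7 ug/mL to 55 ug/mL.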

Compound 3, half-maximal inhibitory concentration: 24 ug/mL
Compound 3: the middle estimate sits 1.2-fold (0.08 log units) below what was measured; measured number inside the range.
By their numbers in this assay, from the lowest: compound 1; then compounds 2 and 3 (each within the scatter of the next).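

In this assay, cyclopropyl on this nitrogen on an aromatic ring keeps the three carbons of propyl and adds a three-membered ring, and the swap gives no change at the digits printed from compound 2 to compound 3 (within the scatter), so closing the chain into a ring makes no difference beyond the scatter for this pair. The distance to the aryl compound holds as well, with a 38-fold higher number from compound 1 to compound 3 (1.58 log units; beyond the scatter), which places both amino groups shown on the weaker side of 4-chlorophenyl. No supporting measurement is available to explain either result.

Going by these compounds, whether a longer chain such as hexylamino, or an aromatic group such as phenylamino, would come closer to compound 1 stays open. On these data alone, it is also open whether the chlorine matters, which a plain phenyl group in the same place would help to settle.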